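A few compounds are considered here, and "the series" means these few. Any claim that something is new, unique, unknown or untested is made for them only; others in the source may bear on it.

Compound 1 `CNCC(=O)N(C)CC(=O)Nc1nc2ccc(OC(F)(F)F)cc2s1`. In an ADME assay for pharmacokinetics, read by LC-MS, in simulated gastric fluid, tested at 0.01 mg/mL (a higher number here means that the compound lasts longer, a lower number that the compound disappears faster), compound 1 gives > 4 h, which is a limit of the assay rather than a number.
Compound 2 `CCNCC(=O)N(C)CC(=O)Nc1nc2ccc(OC(F)(F)F)cc2s1`. In this assay compound 2 gives > 4 h, again a limit.

Compound 2 therefore stands at the limit of > 4 h in this assay, at which 2 of the 2 values shown sit, and nothing places it above or below compound 1. Compound 3 `CC(C)NCC(=O)N(C)CC(=O)Nc1nc2ccc(OC(F)(F)F)cc2s1` differs from compound 2 by methyl in place of hydrogen on a saturated chain carbon bound to an amine nitrogen and a saturated chain carbon; cut one bond further out, the change reads ethylamino to isopropylamino. Within the data shown here, the only measured step that bears on it is a step that the two limits leave unreadable from compound 1 to compound 2, the same kind of change made one carbon earlier, and both of its ends sit at the limit, so its size cannot be read. No readable step is available, and the expectation for compound 3 rests on the two limits alone: the step that the limit leaves unreadable from compound 2 to compound 3 is expected to be none beyond the scatter. Compound 3 is accordingly estimated at 6 h in this assay, within 3 h to 12 h, most likely reported again only as a limit.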

Compound 3, half-life: > 4 h
Compound 3 gave a limit, no number; the forecaster's own chance of this, stated with the estimate: 80%; the middle value lies beyond the limit too.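

Among these compounds, no step among compound 1, compound 2 and compound 3 can be read in this assay, since all three values are limits, not numbers: the limit of > 4 h in this assay, at which 3 of the 3 values shown sit. The compounds shown leave open how long each actually lasts, and whether methyl, ethyl or isopropyl on the amine nitrogen makes any difference in this assay.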